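This account rests on a few compounds, and the source may have more. Where it says the series, first, only, none or still open, it means among the compounds named here.

Measured compounds in a functional assay on SK-BR-3 cells (Homo sapiens) for antiproliferative activity, read by MTT assay, with a stated time of 72 h; a lower number here means a stronger inhibitor, a higher number a weaker inhibitor:
- compound 1, `CCN1CCN(c2cc(C)c3cc(NC(=O)c4ccc(F)cc4)ccc3n2)CC1`: compound 1 gives 19800 nM
- compound 2, `CCNc1cc(C)c2cc(NC(=O)c3ccc(Cl)c(Cl)c3)ccc2n1`: compound 2 gives 28200 nM
- compound 3, `Cc1cc(N(C)C)nc2ccc(NC(=O)c3ccc(Cl)c(Cl)c3)cc12`: for compound 3 the assay returns only a limit, > 50000 nM

Compound 1 holds the lowest of the two numbers shown, with compound 2 the nearest; that gap sits within the scatter, so no order between the two is claimed. Compound 3 sits at the limit of > 50000 nM in this assay, at which 1 of the 3 values shown sits, a limit and not a number. Among the measured compounds shown here, the one measured step is an at least 1.7-fold higher number from compound 2 to compound 3 (0.24 log units; that floor lies within the scatter), an amine change whose floor lies within the scatter; it does not touch the (4-fluorophenyl)carbonyl part.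

Compound 4, `CCN1CCN(c2cc(C)c3cc(NC(=O)c4ccc(F)c(F)c4)ccc3n2)CC1`, differs from compound 1 by fluoro in place of hydrogen on an aromatic carbon. No measured step bears on this change, and the only step shown is within the scatter. The expectation is therefore a number close to that of compound 1, with no step beyond the scatter in either direction. Compound 4 is expected near 18000 nM, with a range from 8000 nM to 45000 nM. The expected step is a 1.1-fold lower number from compound 1 to compound 4 (0.04 log units; within the scatter).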

Compound 4, half-maximal inhibitory concentration: 1980 nM
Compound 4: middle estimate off by 9.1-fold (0.96 log units), on the high side, and the stated range ends above it.
By their numbers in this assay, from the lowest: compound 4; then compounds 1 and 2 (each within the scatter of the next). At a limit, above all of these: compound 3.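

In this assay, among the compounds shown here, going from 4-fluorophenyl to 3,4-difluorophenyl gives a 10-fold lower number from compound 1 to compound 4 (1.00 log units; beyond the scatter) and is the first step to lie beyond the scatter. For the compounds shown here, the only earlier step changed the amine and left the (4-fluorophenyl)carbonyl part untouched, so this is the first reading on that side of the molecule. With the amine held fixed, one fluoro on this aromatic carbon, ortho to a fluoro group, is enough to move the number.

From the compounds shown here alone, whether this step is specific to fluoro stays open: a chloro, methoxy or nitrile group in place of the added fluoro, on the same amine, would test that. Nothing measured in the compounds shown gives a reason for the step.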